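The source may hold more compounds than are shown below. What is called first, only, known or untested is meant among the compounds shown, and "the series" means these compounds.

Working notes on the urea series.

The read-out throughout is an ADME assay on the whole organism with Oryza sativa as the target, tested at 1 uM; a lower number here means a stronger effect, a higher number a weaker effect of the compound at the concentration tested. Compound 1 `Cc1ccc(NC(=O)N[C@H](C)c2ccccc2)cc1` gives 98%. Compound 2 `CCc1cccc(NC(=O)N[C@H](C)c2ccccc2)c1` gives 71%. Compound 3 `CCc1ccc(NC(=O)N[C@H](C)c2ccccc2)cc1` gives 47%.

For the measured compounds named here, the one measured step that changes a single place is a number 51 percentage points lower from compound 1 to compound 3 (beyond the scatter); the change is methyl in place of hydrogen on a saturated chain carbon bound to an aromatic carbon. How the cores of compound 1 and compound 2 differ is not broken down here. Going by the values given here, compound 2 and compound 3 share no counted step either; their values simply show compound 2 standing higher than compound 3, and compound 1 standing higher than compound 2, both gaps beyond the scatter.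

Compound 4 `CC(C)c1cccc(NC(=O)N[C@H](C)c2ccccc2)c1` is not yet measured. It differs from compound 2 by methyl in place of hydrogen on a saturated chain carbon bound to an aromatic carbon and a saturated chain carbon. This is the same kind of change as the step from compound 1 to compound 3, but not the same: there the place was a saturated chain carbon bound to an aromatic carbon, here it is a saturated chain carbon bound to an aromatic carbon and a saturated chain carbon, and the core carries the chain in a different arrangement.

Among the compounds with values here, with only one precedent, a downward step is expected for compound 4 because the only measured instance of this kind of change, a number 51 percentage points lower from compound 1 to compound 3 (beyond the scatter), was large; a somewhat smaller step is estimated, a number 26 percentage points lower from compound 2 to compound 4 (beyond the scatter), since compound 2 starts from 71% and the surroundings of the place differ. Compound 4 is therefore estimated at 45% in this assay, with a likely range from 20% to 72%.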

Compound 4, a percentage reported as activity, at one concentration (the size of the read-out at that concentration, not a potency): 61%
Estimate against measurement, compound 4: 16 percentage points below; low and high end bracket the measured number.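

On the core of compound 2, the same methyl-for-hydrogen change gives in this assay a number 10 percentage points lower from compound 2 to compound 4 (within the scatter), so ethyl to isopropyl does not separate these two compounds in this read-out. The size of the step seen on the core of compound 1 therefore does not carry over to the core of compound 2: the same change on two cores in this assay, a number 51 percentage points lower (beyond the scatter) from compound 1 to compound 3 and a number 10 percentage points lower (within the scatter) from compound 2 to compound 4, 41 percentage points apart, beyond the scatter of two such steps This does not show what sets the two steps apart, since each core offers a single pair and the place differs along with the core, a saturated chain carbon bound to an aromatic carbon in one case and a saturated chain carbon bound to an aromatic carbon and a saturated chain carbon in the other.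

The compounds shown vary only among methyl, ethyl and isopropyl, and they leave open whether a longer chain, a methoxy group or an amine in the same places would give values that follow the core of compound 1 or the core of compound 2. Going by these compounds, with just two instances of the change, it also remains open which of the two step sizes is the more typical for this series, or whether a further core would give a third.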